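Oxetan-3-yl in place of cyclopentyl on the sulfonyl sulfur

The source may report more compounds than this note shows. Statements on the series, on what has been measured and on what is new or still open speak of the compounds shown alone.

In an ADME assay on microsomes from liver (Mus musculus) for metabolic stability, read by LC-MS, with a stated time of 40 min, tested at 0.5 uM (a higher number here means faster removal of the compound, a lower number slower removal), compound 1 (`CC(C)S(=O)(=O)c1cccc(NC(=O)c2cccnc2N2CCC3(CC2)CC3)c1`) gives > 399 mL.min-1.g-1 as a limit of the assay. Compound 2 (`O=C(Nc1cccc(S(=O)(=O)NC2CC2)c1)c1cccnc1N1CCC2(CC1)CC2`) gives > 399 mL.min-1.g-1 as a limit as well. Compound 3 (`O=C(Nc1cccc(S(=O)(=O)C2CCCC2)c1)c1cccnc1N1CCC2(CC1)CC2`) also gives only a limit, > 399 mL.min-1.g-1 in the same assay. Compound 3 therefore has no number of its own and stands with the other two at the limit of > 399 mL.min-1.g-1 in this assay, at which 3 of the 3 values shown sit, in these notes.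

The change to compound 4 (`O=C(Nc1cccc(S(=O)(=O)C2COC2)c1)c1cccnc1N1CCC2(CC1)CC2`) is oxetan-3-yl in place of cyclopentyl on a sulfonyl sulfur and puts oxetan-3-yl in place of cyclopentyl on a sulfonyl sulfur.

The measured changes on that sulfur are a step that the two limits leave unreadable from compound 1 to compound 3 and a step that the two limits leave unreadable from compound 2 to compound 3 and a step that the two limits leave unreadable from compound 1 to compound 2 in turn. None of them has a readable size, so they set no scale for this assay here. The expected step is an at least 1.3-fold lower number from compound 3 to compound 4 (0.12 log units; that floor lies within the scatter) and it is estimated, with low confidence, to point towards slower removal. The estimate for compound 4 is 300 mL.min-1.g-1 with an expected range from 130 mL.min-1.g-1 to 520 mL.min-1.g-1 and a further limit remains quite possible.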

Compound 4, intrinsic clearance in microsomes: 385 mL.min-1.g-1
The estimate for compound 4 lay 1.3-fold (0.11 log units) below the measured number; the range from low to high includes it.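

In this assay, for the compounds shown here, compound 4 gives 385 mL.min-1.g-1, the only value on this sulfonyl sulfur that is a number rather than a limit. Oxetan-3-yl in place of cyclopentyl gives an at least 1.0-fold lower number from compound 3 to compound 4 (0.01 log units; that floor lies within the scatter), in place of cyclopropylamino it gives an at least 1.0-fold lower number from compound 2 to compound 4 (0.01 log units; that floor lies within the scatter), and in place of isopropyl it gives an at least 1.0-fold lower number from compound 1 to compound 4 (0.01 log units; that floor lies within the scatter), so even this change has no step shown beyond the scatter, while the steps among compound 1, compound 2 and compound 3 cannot be read. The position as shown remains largely at the assay's limit: the limit of > 399 mL.min-1.g-1 in this assay, at which 3 of the 4 values shown sit.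

As far as these compounds go, how far compound 1, compound 2 and compound 3 lie past that limit remains open. Also open, from the compounds shown here alone, is whether methyl or a morpholine on the sulfonyl sulfur, or a change elsewhere in the shared core, would give a number clearly lower than that of compound 4.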